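Chloro on the long-chain compound: what to expect

The source may report more compounds than this note shows. Statements on the series, on what has been measured and on what is new or still open speak of the compounds shown alone.

Measured so far in a functional assay on SW480 cells (Homo sapiens) for antiproliferative activity, read by MTT assay, with a stated time of 48 h; on this read-out higher numbers stand for weaker inhibition and lower numbers for stronger inhibition:
Compound 1 (`CCCCCC(CCO)n1cnc2c(N)nc(Cl)nc21`) gives > 50000 nM, which is a limit of the assay.
Compound 2 (`CCCCCCCCC(CCO)n1cnc2c(N)nc(Cl)nc21`) gives 13100 nM.
Compound 3 (`CCCCCCCCCCC(CCO)n1cnc2c(N)ncnc21`) gives 1200 nM.

Compound 3 holds the lowest of the two actual numbers, and the gap up to compound 2 lies beyond the scatter. Compound 4 (`CCCCCCCCCCC(CCO)n1cnc2c(N)nc(Cl)nc21`) keeps the chain of compound 3 and makes one change: chloro in place of hydrogen on an aromatic carbon. Among the measured compounds shown here, no measured pair shows this change alone. The nearest evidence is a chain step among the chloro compounds: an at least 3.8-fold lower number from compound 1 to compound 2 (0.58 log units; beyond the scatter). Compound 4 has the chloro and a longer chain than compound 2, so that step suggests a number lower than that of compound 2. Compound 3 differs from compound 2 in both places, so part of its lower number may belong to the missing chloro. A modest rise from compound 3 is therefore expected in this assay. The expected change is a 2.1-fold higher number from compound 3 to compound 4 (0.32 log units; beyond the scatter). Compound 4 is estimated at 2500 nM, with an expected range from 800 nM to 9000 nM.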

Compound 4, half-maximal inhibitory concentration: 13100 nM
Estimate against measurement, compound 4: 5.2-fold (0.72 log units) below; the measured number lies above the stated range.
By their numbers in this assay, from the lowest: compound 3; then compounds 2 and 4 (each within the scatter of the next). At a limit, above all of these: compound 1.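

In this assay, among the compounds shown here, the single change from hydrogen to chloro on the aromatic carbon between two ring nitrogen atoms gives an 11-fold higher number from compound 3 to compound 4 (1.04 log units; beyond the scatter), so on this long chain the position does not tolerate chloro without a large loss. Among the chloro compounds, the chain still matters at the short end, with an at least 3.8-fold lower number from compound 1 to compound 4 (0.58 log units; beyond the scatter), but the gain does not continue, with no change at the digits printed from compound 2 to compound 4 (within the scatter), so the added ethyl does not recover what chloro loses. The value of compound 1 is a limit, so the first of these two steps gives only a minimum size: the limit of > 50000 nM in this assay, at which 1 of the 4 values shown sits.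

On these data alone, it remains open whether fluoro or an amine on this same aromatic carbon would behave as chloro does. As far as these compounds go, it is also open whether a longer chain would change the number of a chloro compound, or how chain length acts when hydrogen stays on that carbon.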